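Extending the Methoxy Group of Compound 1

A few compounds are considered here, and "the series" means these few. Any claim that something is new, unique, unknown or untested is made for them only; others in the source may bear on it.

Of the compounds shown here, two of this set have so far been measured in an assay on RBL-1 cells with Polyunsaturated fatty acid 5-lipoxygenase (Rattus norvegicus) as the target; on this read-out lower numbers stand for stronger inhibition and higher numbers for weaker inhibition. Compound 1 `COc1c(Cc2ccccc2)ccc2ccccc12` gives 55000 nM in this assay, the higher of the two numbers and thus the weaker inhibition. Compound 2 `O=C(O)c1cc(Cc2ccccc2)c(O)c2ccccc12` gives 5800 nM in this assay, a clearly lower number, and the gap between the two lies beyond the usual scatter. Among the compounds with values here, compound 2 differs from compound 1 in more than one place, so no single structural step joins them; their two values show only that compound 1 stands at the weak end of what has been seen.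

Compound 3 `OCCOc1c(Cc2ccccc2)ccc2ccccc12` has not yet been measured. It differs from compound 1 by hydroxymethyl in place of hydrogen on a saturated chain carbon bound to an oxygen on an aromatic ring. Within the data shown here, no measured pair shows a change of this kind, so nothing seen so far says how large its effect will be. Starting from compound 1 with 55000 nM, the author expects the step of a 1.4-fold lower number from compound 1 to compound 3 (0.14 log units; within the scatter) to stay within the scatter, toward a slightly lower number if anything. Compound 3 is therefore expected to give about 40000 nM in this assay, within a range from 12000 nM to 130000 nM.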

Compound 3, half-maximal inhibitory concentration: 40000 nM
Compound 3: middle estimate and measured number agree at the digits printed; the measured number falls inside the stated range.
By their numbers in this assay, from the lowest: compound 2; then compounds 3 and 1 (each within the scatter of the next).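

In this assay, within the data shown here, the change from methoxy to 2-hydroxyethoxy gives a 1.4-fold lower number from compound 1 to compound 3 (0.14 log units; within the scatter) and so provides the first reading at this position of the core. Hydroxymethyl in place of hydrogen on a saturated chain carbon bound to an oxygen on an aromatic ring, a change that adds one hydrogen-bond donor and one hydrogen-bond acceptor, therefore leaves compound 3 indistinguishable from compound 1 on this read-out, with no shift beyond the scatter in either direction. No supporting evidence is available that could explain this result.

On these data alone, this single step covers only the 2-hydroxyethoxy group, so it remains open whether a longer chain, a carboxylic acid or an amine at this position would move the number beyond the scatter. As far as these compounds go, it also remains open whether hydroxymethyl would again make so little difference on a core carrying other changes, since this change has been read only on the core of compound 1.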